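The source may report more compounds than this note shows. Statements on the series, on what has been measured and on what is new or still open speak of the compounds shown alone.

Compound 1 `CN1CCCC1CCn1nc(Cc2ccc(Cl)cc2)c2ccccc2c1=O` pairs a chlorophenyl group with a methylpyrrolidine-bearing chain on the shared core. In an assay for binding affinity to Alpha-1B adrenergic receptor (Homo sapiens) (a higher number here means a weaker inhibitor, a lower number a stronger inhibitor), compound 1 gives 316 nM. Compound 2 `CN1CCC[C@@H]1Cn1nc(Cc2ccc(F)cc2)c2ccccc2c1=O` gives 79.4 nM in this assay. Compound 3 `COc1cccc(Cc2nn(C[C@H]3CCCN3C)c(=O)c3ccccc23)c1` reaches only > 1990 nM in this assay, which is a limit rather than a number. Of the two numbers available, compound 1 stands highest, with compound 2 the nearer and lower. Going by the values given here, the only measured change in one place, an at least 25-fold higher number from compound 2 to compound 3 (1.39 log units; beyond the scatter), concerns the aryl group and says nothing about the amine chain. Compound 4 `CN(C)CCCn1nc(Cc2ccc(Cl)cc2)c2ccccc2c1=O` differs from compound 1 by (dimethylamino)methyl in place of 1-methylpyrrolidin-2-yl on a saturated chain carbon, two bonds along the chain from an aromatic nitrogen. Among the compounds with values here, no measured step tests such a change, so the expectation is loose. Compound 4 is expected to give about 400 nM, within 130 nM to 1300 nM. The expected step is a 1.3-fold higher number from compound 1 to compound 4 (0.10 log units; within the scatter).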

Compound 4, inhibition constant: 316 nM
Estimate against measurement, compound 4: 1.3-fold (0.10 log units) above; the range from low to high includes it.
By their numbers in this assay, from the lowest: compound 2; then compounds 1 and 4 (each within the scatter of the next). At a limit, above all of these: compound 3.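

Going by these compounds alone, this is the first measured step at the amine chain rather than the aryl group. Replacing 2-(1-methylpyrrolidin-2-yl)ethyl with the ring-free 3-(dimethylamino)propyl gives no change at the digits printed from compound 1 to compound 4 (within the scatter), so for this pair in this assay the pyrrolidine ring is not required to keep the affinity. No data shown here explain why the two chains read alike.

As far as these compounds go, whether this holds with the (1-methylpyrrolidin-2-yl)methyl chain of compound 2 remains open. So does the effect of a piperidine ring or a primary amine at the chain end.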